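Ethoxy to methylcarbamoyl on the oxane carbon

The source may hold more compounds than are shown below. What is called first, only, known or untested is meant among the compounds shown, and "the series" means these compounds.

Compound 1 `CCOC1(c2cc(F)cc(OCc3ccc(-n4ccnc4C)cc3)c2)CCOCC1` and compound 2 `Cc1nccn1-c1ccc(COc2cc(F)cc(C3(S(C)(=O)=O)CCOCC3)c2)cc1` have been measured in an assay on blood for inhibition of Polyunsaturated fatty acid 5-lipoxygenase (Homo sapiens); a lower number here means a stronger inhibitor, a higher number a weaker inhibitor.

Among the measured compounds shown here, compound 1 gives 80 nM, the only plain number obtained so far in this assay. Compound 2 gives > 1000 nM, which is a limit of the assay and not a number. The step from compound 1 to compound 2, methylsulfonyl in place of ethoxy on a saturated ring carbon, reads an at least 12-fold higher number from compound 1 to compound 2 (1.09 log units; beyond the scatter); this rests on (the limit of > 1000 nM in this assay, at which 1 of the 2 values shown sits).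

Compound 3 `CNC(=O)C1(c2cc(F)cc(OCc3ccc(-n4ccnc4C)cc3)c2)CCOCC1` differs from compound 1 in one place: methylcarbamoyl in place of ethoxy on a saturated ring carbon. For the measured compounds named here, the only measured step at this position is the one just described, and it was large and toward weaker inhibition. A weakening step in this assay is therefore expected for the change, a 7.5-fold higher number from compound 1 to compound 3 (0.88 log units; beyond the scatter), with a real chance that only a limit is returned. Compound 3 is estimated at 600 nM, with a range from 150 nM to 3000 nM.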

Compound 3, half-maximal inhibitory concentration: 280 nM
For compound 3 the middle estimate is 2.1-fold (0.33 log units) above the measured one; the measured number falls inside the stated range.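

In this assay, methylcarbamoyl weakens inhibition relative to ethoxy, but the result remains a plain number: a 3.5-fold higher number from compound 1 to compound 3 (0.54 log units; beyond the scatter). At this carbon, the two replacements for ethoxy also separate, with an at least 3.5-fold lower number from compound 2 to compound 3 (0.55 log units; beyond the scatter). Compound 2 stands at a limit of the assay and not at a number, so this second step has only one measured end: the limit of > 1000 nM in this assay, at which 1 of the 3 values shown sits.

Open, on these data alone, is how a dimethylcarbamoyl group, which has no amide hydrogen, would read at this position, and whether a methoxy group or a longer alkoxy chain would give a lower number than compound 1. Also open, as far as these compounds go, is whether the same order of ethoxy, methylcarbamoyl and methylsulfonyl would hold with any change elsewhere in the shared core.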